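The compounds below may be only part of what the source reports. "The series", "measured", "known", "first", "only" and "open" are said of these compounds alone.

Measured compounds:
compound 1 `ClCc1ccccc1Cn1cnc2c(Cl)nc(Cl)nc21`, 3380 nM
compound 2 `ClCc1ccccc1Cn1cnc2ncnc(Cl)c21`, 20400 nM

In a functional assay on SF-295 cells (Homo sapiens) for cytotoxicity, read by sulforhodamine B assay, with a stated time of 48 h (on this read-out higher numbers stand for weaker inhibition of growth and lower numbers for stronger inhibition of growth), compound 1 gives 3380 nM and compound 2 gives 20400 nM. Compound 2 holds the highest number of the two, and its gap to compound 1 lies beyond the scatter. Compound 3 `ClCc1ccccc1Cn1cnc2nc(Cl)nc(Cl)c21` differs from compound 2 by chloro in place of hydrogen on an aromatic carbon. For the measured compounds named here, no measured pair shows this change on its own, so there is nothing direct to lean on for the size of the step in this assay; a moderate lowering of the number is expected rather than none. Compound 3 is expected at 8000 nM, within 2500 nM to 25000 nM, an estimated step of a 2.6-fold lower number from compound 2 to compound 3 (0.41 log units; beyond the scatter).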

Compound 3, concentration for total growth inhibition: 35500 nM
The estimate for compound 3 lay 4.4-fold (0.65 log units) below the measured number, and the stated range ends below it.
By their numbers in this assay, from the lowest: compound 1; then compounds 2 and 3 (each within the scatter of the next).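

In this assay, chloro in place of hydrogen on the aromatic carbon between two ring nitrogen atoms gives a 1.7-fold higher number from compound 2 to compound 3 (0.24 log units; within the scatter). At this position, the change therefore cannot be told apart from repeat-measurement noise, so this single pair gives no sign that the added chloro group alters growth inhibition. No supporting data bear on this result.

Going by these compounds, whether an amine or a methoxy group on the same carbon would separate from compound 2 remains open. So does the contribution of the chloro group shared by compound 2 and compound 3.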